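Replacing cyclopropyl with cyclopentyl in compound 2

A few compounds are considered here, and "the series" means these few. Any claim that something is new, unique, unknown or untested is made for them only; others in the source may bear on it.

Measured so far in an ADME assay on liver (Mus musculus) for metabolic stability, read by LC-MS, using microsomes and NADPH; on this read-out lower numbers stand for a less stable compound and higher numbers for a more stable compound:
Compound 1 `CCCN(Cc1ccc(OCCN2C(=O)CCC2=O)c(C)c1)C(CC(=O)O)c1ccc(Cl)cc1`: 75%
Compound 2 `Cc1cc(CN(CC2CC2)C(CC(=O)O)c2ccc(Cl)cc2)ccc1OCCN1C(=O)CCC1=O`: 83%

Among the measured compounds shown here, compound 2, at 83%, stands level with compound 1, the only other compound measured, within the usual scatter. Compound 3 `Cc1cc(CN(CC2CCCC2)C(CC(=O)O)c2ccc(Cl)cc2)ccc1OCCN1C(=O)CCC1=O` has not yet been measured in this assay. It carries cyclopentyl in place of cyclopropyl on a saturated chain carbon bound to an amine nitrogen. For the measured compounds named here, one measured step bears on this place, the change from ethyl to cyclopropyl, a number 8 percentage points higher from compound 1 to compound 2 (within the scatter). That step is small and involves a different pair of groups, so it offers only loose guidance. A modest drop in this assay, no larger than the scatter, is therefore expected. The estimated change is a number 9 percentage points lower from compound 2 to compound 3 (within the scatter). Compound 3 is expected at 74%, with an estimated range from 55% to 88%.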

Compound 3, percent of the compound remaining: 52%
Compound 3: the middle estimate sits 22 percentage points above what was measured; the measured number lies below the stated range.
By their numbers in this assay, from the lowest: compound 3; then compounds 1 and 2 (each within the scatter of the next).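

In this assay, the position on a saturated chain carbon bound to an amine nitrogen turns out not to be indifferent to the group it carries, which compounds 1 and 2 alone could not show, since ethyl and cyclopropyl stood within the scatter of each other. Cyclopentyl in place of cyclopropyl gives a number 31 percentage points lower from compound 2 to compound 3 (beyond the scatter), and cyclopentyl in place of ethyl gives a number 23 percentage points lower from compound 1 to compound 3 (beyond the scatter), so the loss appears against both smaller groups. Nothing available explains this loss.

Going by these compounds, whether the loss follows the ring itself or only the carbon count stays open: cyclobutyl and an open pentyl chain would help separate the two. On these data alone, it is also open whether a tetrahydrofuranyl ring, with an ether oxygen in place of one ring carbon, would behave like cyclopentyl in this position.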